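Acyl Hydrazide Variation in an Adenosine Receptor Binding Series

A few compounds are considered here, and "the series" means these few. Any claim that something is new, unique, unknown or untested is made for them only; others in the source may bear on it.

Measured so far in an assay on CHO cells for displacement of a labelled ligand from adenosine receptor A3 (Homo sapiens); a higher number here means a weaker inhibitor, a lower number a stronger inhibitor:
compound 1 `CCNC(=O)[C@H]1O[C@@H](n2cnc3c(NNC(=O)c4ccc(Cl)cc4)ncnc32)[C@H](O)[C@@H]1O`: > 5000 nM
compound 2 `CCNC(=O)[C@H]1O[C@@H](n2cnc3c(NNC(=O)c4ccccc4)nc(Cl)nc32)[C@H](O)[C@@H]1O`: > 5000 nM
compound 3 `CCNC(=O)[C@H]1O[C@@H](n2cnc3c(NNC(=O)c4cccs4)nc(Cl)nc32)[C@H](O)[C@@H]1O`: > 5000 nM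

Each of these three values is a limit of this assay and not a number. Compound 1 gives only the limit > 5000 nM. Compound 2 gives only the limit > 5000 nM. Compound 3 gives only the limit > 5000 nM. Among the compounds with values here, the single step between measured compounds that differ in one place, a step that the two limits leave unreadable from compound 2 to compound 3, cannot be read because both of its ends sit at the limit of > 5000 nM in this assay, at which 3 of the 3 values shown sit. Compound 3 therefore stands at the limit of this assay, together with the two other values, and no ordering among them can be drawn.

The step to compound 4 `CCNC(=O)[C@H]1O[C@@H](n2cnc3c(NNC(=O)c4cc(-c5ccccc5)on4)nc(Cl)nc32)[C@H](O)[C@@H]1O` is 5-phenyl-1,2-oxazol-3-yl in place of thiophen-2-yl on a carbonyl carbon. Within the data shown here, no measured step bears on this change, and the only step available is itself unreadable. With every value shown at the limit, the estimate for compound 4 is 8000 nM, within 2000 nM to 30000 nM, most likely reported again as a limit. The step that this estimate implies is expected to be a step that the limit leaves unreadable from compound 3 to compound 4, with no direction that the data can support.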

Compound 4, inhibition constant: > 5000 nM
Compound 4 was reported as a limit; the forecaster's own chance of this, stated with the estimate: 80%; the middle value lies beyond the limit too.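

In this assay compound 4 gives > 5000 nM, again a limit and not a number. Its steps from compound 2 and compound 3 therefore cannot be read: the limit of > 5000 nM in this assay, at which 4 of the 4 values shown sit.

The compounds shown leave open how the groups on the carbonyl carbon rank against one another in this assay.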